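Plasma half-life of isosorbide-like diesters carrying acetylsalicylate

A few compounds are considered here, and "the series" means these few. Any claim that something is new, unique, unknown or untested is made for them only; others in the source may bear on it.

Measured so far in an ADME assay on a cell-free system (plasma, Homo sapiens) for metabolic stability, with Plasma (Rattus norvegicus) as the target, read by HPLC, at pH 7.4; a higher number here means that the compound lasts longer, a lower number that the compound disappears faster:
Compound 1, `CC(=O)Oc1ccccc1C(=O)O[C@H]1CO[C@H]2[C@@H]1OC[C@H]2OC(=O)c1ccnn1C`: 0.0642 h
Compound 2, `CC(=O)Oc1ccccc1C(=O)O[C@H]1CO[C@H]2[C@@H]1OC[C@H]2OC(=O)c1ccc(O)cc1`: 0.0198 h
Compound 3, `CC(=O)Oc1ccccc1C(=O)O[C@H]1CO[C@H]2[C@@H]1OC[C@H]2OC(=O)c1cccnc1`: 0.00617 h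

All three share the same core, differing only in the group on one carbonyl carbon. Compound 2 stands second highest of the three: the move to compound 3 is a 3.2-fold lower number from compound 2 to compound 3 (0.51 log units; beyond the scatter), while the move from compound 1 to compound 2 is a 3.2-fold lower number from compound 1 to compound 2 (0.51 log units; beyond the scatter), so compound 2 sits in the middle, with both neighbours beyond the scatter.

Compound 4, `CC(=O)Oc1ccccc1C(=O)O[C@H]1CO[C@H]2[C@@H]1OC[C@H]2OC(=O)CO[N+](=O)[O-]`, is not yet measured. It differs from compound 2 as follows: (nitrooxy)methyl in place of 4-hydroxyphenyl on a carbonyl carbon. Within the data shown here, every measured step swaps one ring for another ring on that carbonyl carbon; none swaps a ring for a group without a ring, so no measured step bears directly on this change. The widest measured step, a 10-fold lower number from compound 1 to compound 3 (1.02 log units; beyond the scatter), shows that this position does move the read-out. With no direct guide, a modest lowering is expected for compound 4, a 2.0-fold lower number from compound 2 to compound 4 (0.30 log units; within the scatter), with a wide range. The estimate for compound 4 in this assay is therefore 0.01 h, between 0.003 h and 0.04 h.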

Compound 4, half-life: 0.015 h
Estimate against measurement, compound 4: 1.5-fold (0.18 log units) below, and the stated range covers the measured number.
By their numbers in this assay, from the lowest: compound 3; then compounds 4 and 2 (each within the scatter of the next); then compound 1.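

In this assay, a group without a ring can take this place on the carbonyl carbon and leave the number within the scatter: (nitrooxy)methyl in place of 4-hydroxyphenyl gives a 1.3-fold lower number from compound 2 to compound 4 (0.12 log units; within the scatter). Against the other two compounds the same group does stand clear, with a 2.4-fold higher number from compound 3 to compound 4 (0.39 log units; beyond the scatter) and a 4.3-fold lower number from compound 1 to compound 4 (0.63 log units; beyond the scatter), so compound 4, which has no ring in this group, lies inside the span set by the ring-bearing compounds 1 and 3, and the presence of a ring alone does not decide the half-life in this small set. The data shown offer no measured reason for any of these differences.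

With only one group of this kind, the compounds shown cannot separate the part played by the nitrooxy end from that of the single carbon holding it, and a plain methyl, a longer chain ending in nitrooxy, or an amine or a carboxylic acid in its place would be needed to do so. Among these compounds, the half-lives also leave open which ester of these diesters is the first to go.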